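Phenyl in place of thiophen-2-yl on the triple bond

The source may hold more compounds than are shown below. What is called first, only, known or untested is meant among the compounds shown, and "the series" means these compounds.

In a functional assay on LN-229 cells (Homo sapiens) for antiproliferative activity, with a stated time of 72 h (a higher number here means a weaker inhibitor, a lower number a stronger inhibitor), compound 1 `CCCCC#Cc1cc([C@@H]2O[C@H](CO)[C@@H](O)[C@H]2O)n2ncnc(N)c12` gives 1000 nM and compound 2 `Nc1ncnn2c([C@@H]3O[C@H](CO)[C@@H](O)[C@H]3O)cc(C#CC3CC3)c12` gives 30 nM. Compound 3 `Nc1ncnn2c([C@@H]3O[C@H](CO)[C@@H](O)[C@H]3O)cc(C#Cc3cccs3)c12` reads > 100000 nM, which is a limit of the assay and not a number. Compound 4 `Nc1ncnn2c([C@@H]3O[C@H](CO)[C@@H](O)[C@H]3O)cc(C#Cc3ccccc3)c12` differs from it as follows: phenyl in place of thiophen-2-yl on a triple-bonded carbon. The steps into thiophen-2-yl, an at least 100-fold higher number from compound 1 to compound 3 (2.00 log units; beyond the scatter) and an at least 3300-fold higher number from compound 2 to compound 3 (3.52 log units; beyond the scatter), are both large, as is a 33-fold lower number from compound 1 to compound 2 (1.52 log units; beyond the scatter), so the group on the triple-bonded carbon counts heavily in these three compounds. None of these steps exchanges one aromatic ring for another. An aromatic ring stays in place here, so the estimated step is an at least 3.3-fold lower number from compound 3 to compound 4 (0.52 log units; beyond the scatter), towards a lower number, and a further reading at the limit is also expected to be possible. Compound 4 is estimated at 30000 nM, with an expected range from 2000 nM to 100000 nM.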

Compound 4, half-maximal inhibitory concentration: 88000 nM
The estimate for compound 4 lay 2.9-fold (0.47 log units) below the measured number; the range from low to high includes it.
By their numbers in this assay, from the lowest: compound 2; then compound 1; then compound 4. At a limit, above all of these: compound 3.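

Phenyl on the triple-bonded carbon gives a readable number, and it stays far from the two non-aromatic groups: a 2900-fold higher number from compound 2 to compound 4 (3.47 log units; beyond the scatter) and an 88-fold higher number from compound 1 to compound 4 (1.94 log units; beyond the scatter). Both aromatic rings shown therefore sit on the weak side of butyl and cyclopropyl at this position. The reading of an at least 1.1-fold lower number from compound 3 to compound 4 (0.05 log units; that floor lies within the scatter) starts from a limit and not a number, and its floor lies within the scatter, so thiophen-2-yl and phenyl cannot be put in order: the limit of > 100000 nM in this assay, at which 1 of the 4 values shown sits.

Open, on these data alone, is how a chain longer than butyl, a cyclobutyl group or an amine on the phenyl ring would read here.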